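Series notes: chain growth and growth inhibition

The source may hold more compounds than are shown below. What is called first, only, known or untested is meant among the compounds shown, and "the series" means these compounds.

Measured in a functional assay on G-361 cells (Homo sapiens) for cytotoxicity, read by sulforhodamine B assay; on this read-out lower numbers stand for stronger inhibition of growth and higher numbers for weaker inhibition of growth:

compound 1, `CCCNc1nc(C)nc2c1cnn2-c1ccccc1`, gives 36000 nM
compound 2, `CCNc1nc(C)nc2c1cnn2-c1ccccc1`, gives 38700 nM
compound 3, `CCCCNc1nc(CC)nc2c1cnn2-c1ccccc1`, gives 2020 nM

Compound 3 stands lowest of the three numbers; compound 1 is nearest to it, compound 2 furthest, and both gaps lie beyond the scatter. The difference between the core of compound 2 and the core of compound 3 is not broken down here.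

The unmeasured compound 4, `CCCCNc1nc(C(C)C)nc2c1cnn2-c1ccccc1`, differs from compound 3 by methyl in place of hydrogen on a saturated chain carbon bound to an aromatic carbon and a saturated chain carbon. The same kind of change is already on record between compound 2 and compound 1: methyl in place of hydrogen on a saturated chain carbon, two bonds along the chain from a nitrogen on an aromatic ring, which made a 1.1-fold lower number from compound 2 to compound 1 (0.03 log units; within the scatter). The surroundings of the place are not the same, though: in the measured pair the methyl enters two bonds along the chain from a nitrogen on an aromatic ring, whereas in compound 4 it enters on a saturated chain carbon bound to an aromatic carbon and a saturated chain carbon. One measured pair is a thin basis, and it comes from a different place on the molecule.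

Going by the values given here, for compound 4 the step from compound 3 is therefore expected to be small, a 1.1-fold lower number from compound 3 to compound 4 (0.05 log units; within the scatter), because the only comparable change gave a 1.1-fold lower number from compound 2 to compound 1 (0.03 log units; within the scatter), which sat within the scatter. In this assay compound 4 is accordingly estimated at 1800 nM, with the expected range running from 600 nM to 5500 nM.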

Compound 4, concentration for 50% growth inhibition: > 100000 nM
Compound 4: a limit, no number (the forecaster's own chance of this, stated with the estimate: 0%); at least 55-fold (1.74 log units) between middle value and limit.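

In this assay compound 4 gives > 100000 nM, which is a limit of the assay and not a number. Ethyl to isopropyl gives an at least 49-fold higher number from compound 3 to compound 4 (1.69 log units; beyond the scatter), while the methyl-for-hydrogen change on the chain on the nitrogen gives a 1.1-fold lower number from compound 2 to compound 1 (0.03 log units; within the scatter), so in this series the near-silent result on one core does not carry over to the other: the same change on two cores in this assay, a 1.1-fold lower number (0.03 log units; within the scatter) from compound 2 to compound 1 and an at least 49-fold higher number (1.69 log units; beyond the scatter) from compound 3 to compound 4, at least 53-fold (1.72 log units) apart, beyond the scatter of two such steps This shows that the change cannot be read across these two cores by its kind alone, but it does not show what sets the two steps apart, since they differ in the place of the methyl as well as in the core, each rests on a single pair, and the full size of the step to compound 4 stays unknown behind the limit.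

Open, on these data alone, is whether a propyl or a cyclopropyl in place of the isopropyl would stay near compound 3 or fall at the limit with compound 4. Also open, as far as these compounds go, is whether the isopropyl would have the same effect with the propyl chain of compound 1 on the nitrogen, or with a longer chain such as pentyl there.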